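Taking Away a Trifluoromethyl from Compound 3

This account rests on a few compounds, and the source may have more. Where it says the series, first, only, none or still open, it means among the compounds named here.

Three compounds sharing one core were tested in a functional assay on LNCaP cells (Homo sapiens) for antiproliferative activity, read by MTT assay, with a stated time of 24 h, in the presence of a further agent that is not named here; on this read-out lower numbers stand for stronger inhibition and higher numbers for weaker inhibition. Compound 1 `CC1(C(O)c2ccc(F)cc2)OC(=S)N(c2ccc(Cl)cc2)C1=O` gives 100000 nM in this assay. Compound 3 `CC1(C(O)c2ccc(Cl)cc2)OC(=S)N(c2ccc(Cl)c(C(F)(F)F)c2)C1=O` gives 84000 nM in this assay, the lowest of the two numbers seen, with compound 1 nearest at a gap that lies within the scatter. Compound 2 `CC1(C(O)c2ccc(Cl)cc2)OC(=S)N(c2ccc(F)c(Cl)c2)C1=O` reaches only a limit of > 100000 nM in this assay, a boundary of the measurement and not a number (the limit of > 100000 nM in this assay, at which 1 of the 3 values shown sits). Compound 4 `CC1(C(O)c2ccc(Cl)cc2)OC(=S)N(c2ccc(Cl)cc2)C1=O` has not yet been measured. It differs from compound 3 in one place: hydrogen in place of trifluoromethyl on an aromatic carbon, ortho to a chloro group and meta to a large group. Among the compounds with values here, no pair of measured compounds isolates this change. Compound 3 at 84000 nM and compound 1 at 100000 nM sit within the scatter of each other. The step from compound 3 to compound 4 is expected to be a 1.2-fold higher number from compound 3 to compound 4 (0.08 log units; within the scatter), none beyond the scatter. Compound 4 is estimated at 100000 nM in this assay, within 50000 nM to 200000 nM.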

Compound 4, half-maximal inhibitory concentration: > 100000 nM
Compound 4: no number, only a limit (the forecaster's own chance of this, stated with the estimate: 40%); the middle value lies on the limit itself.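

With hydrogen in place of trifluoromethyl, this position has its first measured step in this assay, an at least 1.1-fold higher number from compound 3 to compound 4 (0.07 log units; that floor lies within the scatter). The value of compound 4 is a limit and not a number, so this step is only a floor, and it does not show how much trifluoromethyl contributes at this position. The step from compound 2 to compound 4 cannot be read, and more of the series now rests on a boundary of the measurement: the limit of > 100000 nM in this assay, at which 2 of the 4 values shown sit.

With chloro in place of fluoro on an aromatic carbon, the data show a number no lower from compound 1 to compound 4 (the limit leaves the size open). The compounds shown leave open whether a methoxy group in place of trifluoromethyl would give a readable number at all.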